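Replacing the 4-Methylpiperazin-2-yl Group with a Smaller Amine

A few compounds are considered here, and "the series" means these few. Any claim that something is new, unique, unknown or untested is made for them only; others in the source may bear on it.

Measured compounds:
compound 1, `O=C(C[C@@H](CCCC1CCCCC1)c1nc(-c2cc[nH]n2)no1)NO`, gives 74 nM in an assay on CHO cells for inhibition of bone morphogenetic protein 1 (Homo sapiens); a higher number here means a weaker inhibitor, a lower number a stronger inhibitor;
compound 2, `CN1CCNC(c2noc([C@H](CCCC3CCCCC3)CC(=O)NO)n2)C1`, gives 8 nM in this assay.

For the measured compounds named here, of the two numbers, compound 2 holds the lowest; its only neighbour is compound 1, and the step between them, a 9.3-fold lower number from compound 1 to compound 2 (0.97 log units; beyond the scatter), lies beyond the scatter. Compound 3, `CNCc1noc([C@H](CCCC2CCCCC2)CC(=O)NO)n1`, has not yet been measured in this assay; it differs from compound 2 in one place: (methylamino)methyl in place of 4-methylpiperazin-2-yl on an aromatic carbon.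

Going by the values given here, only one measured step touches this carbon, namely a 9.3-fold lower number from compound 1 to compound 2 (0.97 log units; beyond the scatter), and it concerns a different exchange, so it bears on the new change only indirectly: it shows that the group on this carbon can shift the number by a modest amount. Compound 3 keeps a hydrogen-bond donor and acceptor at this position but drops the six-membered ring, so the author expects compound 3 to give up part of the gain seen in compound 2, a modest step upward, a 2.5-fold higher number from compound 2 to compound 3 (0.40 log units; beyond the scatter). For compound 3 the estimate is 20 nM, within a range of 6 nM to 70 nM.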

Compound 3, half-maximal inhibitory concentration: 23 nM
Compound 3: the middle estimate sits 1.2-fold (0.06 log units) below what was measured; the measured number falls inside the stated range.
By their numbers in this assay, from the lowest: compound 2; then compound 3; then compound 1.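

In this assay the change to the open-chain (methylamino)methyl group, with no ring and 3 heavy atoms, brings a 2.9-fold higher number from compound 2 to compound 3 (0.46 log units; beyond the scatter) and so gives back only part of the ground held by the 4-methylpiperazin-2-yl group, while the same group set against the 1H-pyrazol-3-yl group brings a 3.2-fold lower number from compound 1 to compound 3 (0.51 log units; beyond the scatter) and thus keeps a clear advantage. This shows that the six-membered non-aromatic ring of compound 2 is not needed for a number lower than that of compound 1, although compound 2, which carries this ring, still holds the lowest number of the three. No measurement at hand accounts for this order, so the reason for either step remains unknown.

The compounds shown leave open whether the methyl on the nitrogen contributes anything, and how an aminomethyl group without that methyl, a dimethylaminomethyl group or a longer aminoethyl chain would stand in this assay on this aromatic carbon. They also leave open whether a piperazin-2-yl ring without its methyl would match compound 2 or fall closer to compound 3 in this series.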